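The compounds below may be only part of what the source reports. "The series", "measured", "known", "first", "only" and "open" are said of these compounds alone.

Measured compounds:
- compound 1, `CC(C)c1ccn2ncnc(N[C@H]3CC[C@H](N(C)C)CC3)c12`: 1.3
- compound 2, `CN(C)[C@H]1CC[C@H](Nc2ncnc3sccc23)CC1`: 0.1
- compound 3, `CC(=O)N1CCN([C@H]2CC[C@H](Nc3ncnn4ccc(C(C)C)c34)CC2)CC1`: 2.4

In a physicochemical assay for lipophilicity, using the shake flask method, at pH 7.4 (on this read-out lower numbers stand for lower lipophilicity and higher numbers for higher lipophilicity), compound 1 stands second highest of the three numbers. Its nearest neighbour is compound 3, which sits at 2.4, and furthest from it is compound 2, which sits at 0.1, both beyond the scatter. Among the compounds with values here, the only measured step that changes one place is a number 1.10 log units higher from compound 1 to compound 3 (beyond the scatter), a large rise when 4-acetylpiperazin-1-yl replaces dimethylamino on a saturated ring carbon.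

Compound 4, `CN(C)[C@H]1CC[C@H](Nc2ncnn3ccc([C@H]4CC[C@@H](C(N)=O)CC4)c23)CC1`, differs from compound 1 at a different place: 4-carbamoylcyclohexyl in place of isopropyl on an aromatic carbon. Within the data shown here, no measured step touches this aromatic carbon, so the change from compound 1 to compound 3 does not bear on it directly, and the expectation must rest on the nature of the groups alone. The entering 4-carbamoylcyclohexyl brings more carbon than the isopropyl it replaces, but also one hydrogen-bond donor and one hydrogen-bond acceptor that the isopropyl lacks. These pull in opposite directions, so the expected outcome is a modest fall or no change beyond the scatter.

Compound 4 is therefore estimated at 1 in this assay, within 0.3 to 1.7, an expected step of a number 0.30 log units lower from compound 1 to compound 4 (within the scatter).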

Compound 4, distribution coefficient: 0.1
For compound 4 the middle estimate is 0.90 log units above the measured one, outside the stated range (below it).
By their numbers in this assay, from the lowest: compounds 2 and 4 (each within the scatter of the next); then compound 1; then compound 3.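

In this assay, this aromatic carbon on the five-membered aromatic ring now has a measured step of its own: putting 4-carbamoylcyclohexyl in place of isopropyl gives a number 1.20 log units lower from compound 1 to compound 4 (beyond the scatter), a large fall even though the entering group holds more carbon than the one it replaces. Together with the rise seen when 4-acetylpiperazin-1-yl replaces dimethylamino on a saturated ring carbon, a number 1.10 log units higher from compound 1 to compound 3 (beyond the scatter), this shows that two different places on compound 1 can each carry a large step, one upward and one downward. Nothing measured here gives a reason for the fall at the aromatic carbon.

The change swaps a small chain for a ring bearing a carbamoyl group, so the share of the ring and the share of the carbamoyl cannot be told apart; a plain cyclohexyl at the same aromatic carbon would separate the two. Also open, going by these compounds, is whether a carboxylic acid or a hydroxyl in place of the carbamoyl on that ring would give a step of similar size, and whether the other stereoisomer of the ring would match compound 4.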